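Replacing Bromo with Fluoro in Compound 3

The source may hold more compounds than are shown below. What is called first, only, known or untested is meant among the compounds shown, and "the series" means these compounds.

In a functional assay on M14 cells (Homo sapiens) for cytotoxicity (on this read-out lower numbers stand for stronger inhibition of growth and higher numbers for weaker inhibition of growth), compound 1 `COc1ccc(C2=C(c3ccc(SC)cc3)CC3CCCN3C2=O)cc1C` gives 200 nM and compound 2 `CSc1ccc(C2=C(c3ccc(F)c(F)c3)C(=O)N3CCCC3C2)cc1` gives 300 nM, and a 1.5-fold higher number from compound 1 to compound 2 (0.18 log units; within the scatter) keeps these two together. Compound 3 `CSc1ccc(C2=C(c3ccc(Br)cc3)C(=O)N3CCCC3C2)cc1` gives 9000 nM, the highest number of the three. Compound 4 `CSc1ccc(C2=C(c3ccc(F)cc3)C(=O)N3CCCC3C2)cc1` has not yet been measured. The change is fluoro in place of bromo on an aromatic carbon, para to a large group.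

Among the compounds with values here, no measured step makes this exact exchange. The closest evidence is a 30-fold higher number from compound 2 to compound 3 (1.48 log units; beyond the scatter), where 4-bromophenyl replaces 3,4-difluorophenyl, supported by a 45-fold higher number from compound 1 to compound 3 (1.65 log units; beyond the scatter), where it replaces 4-methoxy-3-methylphenyl. Both are large, and the 3,4-difluorophenyl of compound 2 is the nearest measured match to 4-fluorophenyl. Leaving the 4-bromophenyl group is therefore expected to bring a clear fall in the number, though how much of the gap closes is unknown. The expected change is an 11-fold lower number from compound 3 to compound 4 (1.05 log units; beyond the scatter), beyond the scatter. The estimate for compound 4 is 800 nM, with an expected range from 200 nM to 3000 nM.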

Compound 4, concentration for 50% growth inhibition: 600 nM
Beside the measured number, compound 4's estimate is 1.3-fold (0.12 log units) above it, within the range that was stated.
By their numbers in this assay, from the lowest: compounds 1, 2 and 4 (each within the scatter of the next, the first and the last beyond it); then compound 3.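

In this assay, a 15-fold lower number from compound 3 to compound 4 (1.18 log units; beyond the scatter) isolates the exchange of bromo for fluoro on an aromatic carbon, para to a large group, and shows that this single atom accounts for a large shift with the rest of the structure unchanged. Taking away the other fluoro of the 3,4-difluorophenyl group gives a 2.0-fold higher number from compound 2 to compound 4 (0.30 log units; within the scatter), a step that cannot be told from scatter, whereas a 3.0-fold higher number from compound 1 to compound 4 (0.48 log units; beyond the scatter) leaves a modest gap between the 4-fluorophenyl and 4-methoxy-3-methylphenyl groups. Nothing available here explains why bromo and fluoro differ so sharply at this place.

The compounds shown leave open how chloro, an amine or a carboxylic acid would behave at this place, and whether the numbers follow any order across such groups. Within the data shown here, they also leave open whether the exchange of bromo for fluoro would give a step of similar size with a group other than the one shared by compound 3 and compound 4 on the other aromatic ring.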